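Swapping a phenyl for a pyridin-2-yl on the piperazine

The source may report more compounds than this note shows. Statements on the series, on what has been measured and on what is new or still open speak of the compounds shown alone.

Measured compounds and their values:
- compound 1, `COc1cc(OC)c(-c2nc(N3CCNCC3)nc3ccccc23)c(OC)c1`: 50 ug/mL
- compound 2, `CN1CCN(c2nc(-n3ccc4ccccc43)c3ccccc3n2)CC1`: 4.9 ug/mL
- compound 3, `c1ccc(N2CCN(c3nc(-n4ccc5ccccc54)c4ccccc4n3)CC2)cc1`: 50 ug/mL

In a functional assay on KB cells (Homo sapiens) for antiproliferative activity, read by MTT assay (on this read-out lower numbers stand for stronger inhibition and higher numbers for weaker inhibition), compound 3 gives 50 ug/mL, level with compound 1 at the digits shown, and the two together stand at the highest, that is weakest, number of the three; compound 2 gives 4.9 ug/mL. Among the measured compounds shown here, the one measured step that touches the same position is a 10-fold higher number from compound 2 to compound 3 (1.01 log units; beyond the scatter).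

Compound 4, `c1ccc(N2CCN(c3nc(-n4ccc5ccccc54)c4ccccc4n3)CC2)nc1`, differs from compound 3 in a single place: pyridin-2-yl in place of phenyl on an amine nitrogen in a ring. For the measured compounds named here, no measured step changes a phenyl into a pyridin-2-yl, so the only guide is that the group on this ring nitrogen matters, as the step from compound 2 to compound 3 showed. A group of the same size and ring shape is not expected to move the number far in this assay; the estimate for compound 4 is 40 ug/mL, within 15 ug/mL to 100 ug/mL, which is expected to mean a 1.3-fold lower number from compound 3 to compound 4 (0.10 log units; within the scatter) relative to compound 3.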

Compound 4, half-maximal inhibitory concentration: 50 ug/mL
Estimate against measurement, compound 4: 1.3-fold (0.10 log units) below; measured number inside the range.
By their numbers in this assay, from the lowest: compound 2; then compounds 1, 3 and 4 (each within the scatter of the next).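

In this assay, bringing a nitrogen into the aromatic ring on this amine nitrogen, with phenyl giving way to pyridin-2-yl, gives no change at the digits printed from compound 3 to compound 4 (within the scatter) and so leaves the read-out unmoved. Measured against methyl, the second aromatic ring gives a 10-fold higher number from compound 2 to compound 4 (1.01 log units; beyond the scatter) and weakens inhibition as phenyl did, so the large step seen earlier is not confined to phenyl and now holds for both six-membered aromatic rings shown here. Nothing measured here explains this result.

Still open, as far as these compounds go, is how an ethyl chain, a hydroxyethyl chain or a benzyl group on this ring nitrogen would read, and so whether the number rises gradually from methyl or only with an aromatic ring attached directly. A pyridin-4-yl group would show whether the place of the ring nitrogen matters.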